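Aryl replacement at the shared core: compound 3

The source may report more compounds than this note shows. Statements on the series, on what has been measured and on what is new or still open speak of the compounds shown alone.

Compound 1 `COc1cncc(-c2c(C)nn(-c3nc(-c4ccc(Cl)c(Cl)c4)c(SC(C)C)s3)c2C(=O)O)c1` and compound 2 `CNc1cc(-c2c(C)nn(-c3nc(-c4ccc(Cl)c(Cl)c4)c(SC(C)C)s3)c2C(=O)O)ccn1` share one core and differ only in the aromatic ring attached to it. In a functional assay on BJAB cells (Homo sapiens) for antiproliferative activity, with a stated time of 4 days (on this read-out lower numbers stand for an effect already at smaller amounts and higher numbers for an effect only at larger amounts of compound), compound 1 gives 21000 nM, and compound 2 gives 18000 nM. The step of a 1.2-fold lower number from compound 1 to compound 2 (0.07 log units; within the scatter) stays within the scatter, so compound 2 stands at one end of the two numbers without being separable from compound 1. Compound 3 `COc1ccc(C)cc1-c1c(C)nn(-c2nc(-c3ccc(Cl)c(Cl)c3)c(SC(C)C)s2)c1C(=O)O` carries 2-methoxy-5-methylphenyl in place of 2-(methylamino)pyridin-4-yl on an aromatic carbon. Within the data shown here, the single measured step touches the same site and was flat; the entering ring has no ring nitrogen and no hydrogen-bond donor, a combination the measured pair does not cover. No shift beyond the scatter is therefore expected, and the estimated step of a 1.1-fold higher number from compound 2 to compound 3 (0.05 log units; within the scatter) is taken as small. For compound 3 the expected value in this assay is 20000 nM, with a range from 7000 nM to 60000 nM.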

Compound 3, half-maximal effective concentration: 9500 nM
The estimate for compound 3 lay 2.1-fold (0.32 log units) above the measured number; the range from low to high includes it.
By their numbers in this assay, from the lowest: compounds 3, 2 and 1 (each within the scatter of the next, the first and the last beyond it).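

In this assay, among these compounds, 2-methoxy-5-methylphenyl gives the first step at this position that lies beyond the scatter, modest in size: a 2.2-fold lower number from compound 1 to compound 3 (0.34 log units; beyond the scatter) against the within-scatter a 1.9-fold lower number from compound 2 to compound 3 (0.28 log units; within the scatter) in the same series. Compound 3 thus separates from compound 1 only, and the position accepts a ring of carbon only, without a hydrogen-bond donor, with no loss in this read-out. No measurement at hand accounts for the modest step.

The entering ring differs from both pyridine-type rings in several features at once, so the methoxy group, the methyl group and the absent ring nitrogen cannot be told apart. Still open, from the compounds shown here alone, is how a hydroxy group or a longer ethoxy chain in place of the methoxy group of compound 3 would read out.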